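Swapping the triazole aryl arm on the free phenol scaffold

The compounds below may be only part of what the source reports. "The series", "measured", "known", "first", "only" and "open" are said of these compounds alone.

The series rests on a shared core and is followed in a functional assay on HL-60 cells (Homo sapiens) for cytotoxicity, read by MTT assay, with a stated time of 4 days; a lower number here means a stronger inhibitor, a higher number a weaker inhibitor. Compound 1 `C=C1C(=O)[C@]23C[C@@]1(O)CC[C@H]2c1ccc(OS(=O)(=O)c2ccc(C)cc2)c(C)c1[C@@H]3Cn1cc(-c2ccccn2)nn1` gives 1810 nM. Among the measured compounds shown here, compound 3 `C=C1C(=O)[C@]23C[C@@]1(O)CC[C@H]2c1ccc(O)c(C)c1[C@@H]3Cn1cc(-c2ccccn2)nn1`, which keeps that core but carries a hydrogen in place of the (4-methylphenyl)sulfonyl group, gives 1970 nM; this is the higher of the two numbers given here, and the one step that links them, a 1.1-fold higher number from compound 1 to compound 3 (0.04 log units; within the scatter), is within the scatter. Compound 2 `Cc1ccc(S(=O)(=O)Oc2ccc3c(c2C)[C@H](Cn2cc(-c4ccccc4)nn2)[C@@]24CC(=O)[C@@](C)(CC[C@@H]32)C4)cc1`, built on a different core, reaches only the limit > 20000 nM and so yields no number (the limit of > 20000 nM in this assay, at which 1 of the 3 values shown sits).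

Compound 4 `C=C1C(=O)[C@]23C[C@@]1(O)CC[C@H]2c1ccc(O)c(C)c1[C@@H]3Cn1cc(-c2ccc(C(F)(F)F)cc2)nn1` differs from compound 3 by 4-(trifluoromethyl)phenyl in place of pyridin-2-yl on an aromatic carbon. For the measured compounds named here, no measured step touches this position, and the only step at hand, a 1.1-fold higher number from compound 1 to compound 3 (0.04 log units; within the scatter), concerns the phenol oxygen instead; it gives no direction for the aryl exchange. Compound 4 is therefore expected to stay near compound 3, with a step of a 1.3-fold higher number from compound 3 to compound 4 (0.10 log units; within the scatter) in this assay. The estimated value for compound 4 is 2500 nM, within a range from 800 nM to 8000 nM.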

Compound 4, half-maximal inhibitory concentration: 720 nM
Compound 4: the middle estimate sits 3.5-fold (0.54 log units) above what was measured; measured number below the stated range.
By their numbers in this assay, from the lowest: compound 4; then compounds 1 and 3 (each within the scatter of the next). At a limit, above all of these: compound 2.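

The exchange of pyridin-2-yl for 4-(trifluoromethyl)phenyl gives a 2.7-fold lower number from compound 3 to compound 4 (0.44 log units; beyond the scatter) in this assay, so this position moves the number beyond the scatter, unlike the phenol oxygen in a 1.1-fold higher number from compound 1 to compound 3 (0.04 log units; within the scatter). The entering group has no ring nitrogen and no hydrogen-bond acceptor, so on this core neither is needed in the aryl arm for a number at this level. Nothing shown here accounts for the gain.

The single exchange removes the ring nitrogen and adds the trifluoromethyl group together, so the compounds shown cannot separate the two, and a carboxylic acid or an amine on the same phenyl ring remains untested in this account. From the compounds shown here alone, it also remains open whether the (4-methylphenyl)sulfonyl group on the phenol oxygen would leave the number unchanged alongside 4-(trifluoromethyl)phenyl.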